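A few compounds are considered here, and "the series" means these few. Any claim that something is new, unique, unknown or untested is made for them only; others in the source may bear on it.

Measured compounds and their half-lives:

- compound 1, `C=CCOc1cc(F)cc(C(=O)NNS(=O)(=O)c2ccccc2F)c1`: 0.217 h
- compound 2, `Cc1cc(-c2ncccn2)cc(C(=O)NNS(=O)(=O)c2ccccc2)c1F`: 2.72 h
- compound 3, `Cc1cc(OC(C)C)cc(C(=O)NNS(=O)(=O)c2ccccc2F)c1`: 0.5 h

In an ADME assay on microsomes from liver (Homo sapiens) for metabolic stability, read by HPLC, using NADPH, with a stated time of 60 min, tested at 1 uM, in the presence of a further agent that is not named here (a lower number here means that the compound disappears faster, a higher number that the compound lasts longer), compound 2 gives the highest of the three numbers. Compound 3, the nearest to it, gives 0.5 h, a gap beyond the scatter, and compound 1, the furthest, gives 0.217 h, also beyond the scatter. Among the measured compounds shown here, the two compounds with the shorter half-lives carry an allyloxy or isopropoxy group on the shared core, whereas compound 2 carries a pyrimidin-2-yl group; with only three compounds, no firmer pattern than that can be drawn.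

Compound 4, `Cc1cc(-n2cccn2)cc(C(=O)NNS(=O)(=O)c2ccccc2)c1F`, has not yet been measured in this assay. It differs from compound 2 in one place: 1H-pyrazol-1-yl in place of pyrimidin-2-yl on an aromatic carbon. Both the group that leaves and the group that enters are aromatic rings with two hetero atoms and no donors, so the change is modest in size. The half-life of compound 4 is expected to stay close to that of compound 2, with a step of a 1.7-fold lower number from compound 2 to compound 4 (0.23 log units; within the scatter) that lies within, or at most just at the edge of, the scatter. The estimate for compound 4 in this assay is 1.6 h, within a range from 0.6 h to 4 h.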

Compound 4, half-life in the Homo sapiens assay: 1.25 h
The estimate for compound 4 lay 1.3-fold (0.11 log units) above the measured number; the measured number falls inside the stated range.
By their numbers in the Homo sapiens assay, from the lowest: compound 1; then compound 3; then compound 4; then compound 2.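

Among the compounds shown here, in the Homo sapiens assay the change from pyrimidin-2-yl to 1H-pyrazol-1-yl gives a 2.2-fold lower number from compound 2 to compound 4 (0.34 log units; beyond the scatter) and so shows something the earlier compounds, which differ in more than one place, could not: this aromatic carbon responds to a swap between two rings with the same counts of hetero atoms, donors and acceptors. In a physicochemical assay for solubility, read by nephelometry, measured as kinetic solubility, at pH 2 (a lower number here means a less soluble compound, a higher number a more soluble compound), compound 2 gives 50 ug/mL and compound 4 gives 6.3 ug/mL in a comparison of the same pair. The swap thus lowers both read-outs, and the solubility number falls by the larger step: the measured solubility of compound 2, 50 ug/mL, and of compound 4, 6.3 ug/mL, a 7.9-fold lower number (0.90 log units; beyond the scatter).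

A single pair cannot tell whether half-life and solubility generally move together at this position, or whether the smaller ring itself is what matters. Also open, going by these compounds, is how a group of a different kind on this carbon, such as an amine or a carboxylic acid, would affect half-life and solubility.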